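Compound 4: butyl in place of vinyl

The source may hold more compounds than are shown below. What is called first, only, known or untested is meant among the compounds shown, and "the series" means these compounds.

Measured in a functional assay on HL-60 cells (Homo sapiens) for antiproliferative activity, read by MTT assay (a higher number here means a weaker inhibitor, a lower number a stronger inhibitor), so far:
compound 1 `C=CC[C@@H]1O[C@H](COCc2ccccc2)[C@@H](OCc2ccccc2)[C@H](OCc2ccccc2)[C@@H]1O` gives "not active" (no number reported)
compound 2 `O[C@@H]1[C@@H](OCc2ccccc2)[C@H](OCc2ccccc2)[C@@H](COCc2ccccc2)O[C@H]1CC1CCCCC1` gives 4100 nM
compound 3 `C=CC[C@@H]1O[C@H](COCc2ccccc2)[C@@H](OCc2ccccc2)[C@H](OCc2ccccc2)[C@H]1O` gives 15100 nM

Compound 3 has the higher of the two numbers in this assay and compound 2 the lower, the gap being a 3.7-fold higher number from compound 2 to compound 3 (0.57 log units; beyond the scatter) and thus modest but beyond the scatter. Set against compound 3, compound 1 gives "not active" (no number reported) with no number at all, and the contrast rests on the fact that compounds 1 and 3 differ only in the configuration as drawn alone.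

Compound 4 `CCCCC[C@@H]1O[C@H](COCc2ccccc2)[C@@H](OCc2ccccc2)[C@H](OCc2ccccc2)[C@H]1O` keeps the configuration as drawn of compound 3 and carries butyl in place of vinyl on a saturated chain carbon bound to a saturated ring carbon so the same difference reads allyl to pentyl. For the measured compounds named here, one measured step bears on this change, since vinyl replaced cyclohexyl at that same place. With only a 3.7-fold higher number from compound 2 to compound 3 (0.57 log units; beyond the scatter) to go on, which is a single step and no trend, the move back to a saturated group is expected to lower the number in this assay by a similar or smaller amount. The step expected is a 2.2-fold lower number from compound 3 to compound 4 (0.33 log units; beyond the scatter) and it remains uncertain. The estimate for compound 4 is 7000 nM with 2800 nM to 17000 nM as its expected range.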

Compound 4, half-maximal inhibitory concentration: "not active" (no number reported)
Nothing numeric was reported for compound 4; there is nothing to compare the estimate with.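

In this assay, for the compounds shown here, compound 4 gives "not active" (no number reported) with no figure to set against compound 3, so no step between these two compounds can be read. The compounds shown leave open how far the number of compound 3 (15100 nM) shifts when butyl replaces vinyl on this chain. Nothing shown bears on this result for compound 4.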